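This account rests on a few compounds, and the source may have more. Where it says the series, first, only, none or still open, it means among the compounds named here.

Compound 1 `O=C(CSc1snnc1-c1ccccc1)Nc1ccccc1F` has been tested in an ADME assay on MT4 cells (Homo sapiens) for cytotoxicity (on this read-out higher numbers stand for lower toxicity in this test and lower numbers for higher toxicity in this test), and gives > 361000 nM, which is a limit of the assay and not a number. Compound 1 therefore stands at the limit of > 361000 nM in this assay, at which 1 of the 3 values shown sits, and the two further values shown are limits as well. Compound 2 `Cc1ccc(NC(=O)CSc2snnc2-c2ccccc2)c(Br)c1` gives > 297000 nM in this assay, a limit. Compound 3 `O=C(CSc1snnc1-c1ccccc1)Nc1ccccc1Br` gives > 307000 nM in this assay, likewise a limit. The three steps among them, a step that the two limits leave unreadable from compound 1 to compound 2, a step that the two limits leave unreadable from compound 1 to compound 3 and a step that the two limits leave unreadable from compound 2 to compound 3, are accordingly of unreadable size, since each pair sits between two limits.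

Compound 4 `COc1ccc(-c2nnsc2SCC(=O)Nc2ccccc2F)cc1` is built from compound 1 by methoxy in place of hydrogen on an aromatic carbon. Going by the values given here, none of the measured steps in this assay can be read, so they give no direction for this change; they show only that variation of the amide-side aryl ring has left every compound at the limit. On that basis compound 4 is expected to behave like compound 1 and to remain at a limit, so that the step from compound 1 to compound 4 is estimated to be an at least 1.0-fold lower number from compound 1 to compound 4 (0.02 log units; that floor lies within the scatter). For compound 4 the estimated value in this assay is 340000 nM, with an expected range from 150000 nM to 700000 nM.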

Compound 4, half-maximal cytotoxic concentration: > 332000 nM
Compound 4 ended at the assay's limit; the forecaster's own chance of this, stated with the estimate: 80%; the middle value is on the limit's open side.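

In this assay compound 4 gives > 332000 nM, which is a limit and not a number. Going by these compounds alone, compound 1 gives > 361000 nM, also a limit, so no step between compound 1 and compound 4 can be read. The compounds shown leave open whether methoxy in place of hydrogen changes this read-out at all.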